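This account rests on a few compounds, and the source may have more. Where it says the series, first, only, none or still open, it means among the compounds named here.

Compound 1 `COc1ccc(OCC2=NCCO2)cc1`: 90%
Compound 2 `Clc1ccc(OCC2=NCCO2)cc1`: 90%

In a toxicity assay on the whole organism with Rattus norvegicus as the target, at a dose of 400 mg/kg by the oral route (a lower number here means a weaker effect, a higher number a stronger effect of the compound at the dose given), compound 2 gives 90% and stands level with compound 1, the step from compound 1 to compound 2 being no change at the digits printed from compound 1 to compound 2 (within the scatter) after chloro replaced methoxy on an aromatic carbon. Compound 3 `Brc1ccc(OCC2=NCCO2)cc1` differs from compound 2 in one place: bromo in place of chloro on an aromatic carbon. For the measured compounds named here, the only step measured so far, no change at the digits printed from compound 1 to compound 2 (within the scatter), swapped one substituent for another at this same carbon without moving the number, so a step within the scatter is expected in this assay, namely no change at the digits printed from compound 2 to compound 3 (within the scatter). Compound 3 is therefore estimated at 90%, between 80% and 97%.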

Compound 3, a percentage reported as activity, at one dose (the size of the read-out at that dose, not a potency): 100%
The estimate for compound 3 lay 10 percentage points below the measured number; measured number above the stated range.
By their numbers in this assay, from the lowest: compounds 1, 2 and 3 (each within the scatter of the next).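

With bromo in place of chloro on this aromatic carbon, this assay shows a number 10 percentage points higher from compound 2 to compound 3 (within the scatter), and bromo in place of methoxy shows a number 10 percentage points higher from compound 1 to compound 3 (within the scatter). A third substituent at this carbon therefore still leaves all the compounds within the scatter of one another, so this assay does not separate methoxy, chloro and bromo here. Nothing available explains the higher printed number for compound 3. Going by these compounds, whether an amine or a carboxylic acid at this carbon would separate from these three remains open. So does the effect of moving bromo elsewhere on the aromatic ring.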